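Compound 3: one more exchange on a carbonyl carbon

This account rests on a few compounds, and the source may have more. Where it says the series, first, only, none or still open, it means among the compounds named here.

For the measured compounds named here, in an ADME assay on Caco-2 cells (Homo sapiens) for permeability, in the apical to basolateral direction, at pH 7.4 (on this read-out lower numbers stand for lower permeability and higher numbers for higher permeability), compound 1 (`Cc1csc(C(=O)N[C@H]2CN(S(=O)(=O)c3ccccc3)C[C@@H]2C(=O)N[C@H]2CCCNC2)n1`) gives 0.18 10^-6 cm/s and compound 2 (`O=C(N[C@H]1CN(S(=O)(=O)c2ccccc2)C[C@@H]1C(=O)N[C@H]1CCCNC1)c1cc(C2CC2)n[nH]1`) gives 0.39 10^-6 cm/s as the higher of the two numbers so far. Compound 3 (`O=C(N[C@H]1CN(S(=O)(=O)c2ccccc2)C[C@@H]1C(=O)N[C@H]1CCCNC1)c1cn(C2CC2)cn1`) keeps the shared core and carries 1-cyclopropyl-1H-imidazol-4-yl in place of 3-cyclopropyl-1H-pyrazol-5-yl on a carbonyl carbon, with the same atoms joined differently. Going by the values given here, the one measured step at this place (a 2.2-fold higher number from compound 1 to compound 2 (0.34 log units; beyond the scatter)) was modest, started from another group and gives no direction for this exchange, so this assay is expected to show no change beyond the scatter. The expected step (a 1.2-fold higher number from compound 2 to compound 3 (0.06 log units; within the scatter)) is therefore small. For compound 3 the estimated value is 0.45 10^-6 cm/s (range 0.18 10^-6 cm/s to 1.1 10^-6 cm/s).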

Compound 3, apparent permeability: 0.48 10^-6 cm/s
Estimate against measurement, compound 3: 1.1-fold (0.03 log units) below; measured number inside the range.
By their numbers in this assay, from the lowest: compound 1; then compounds 2 and 3 (each within the scatter of the next).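

In this assay, the exchange of 3-cyclopropyl-1H-pyrazol-5-yl for 1-cyclopropyl-1H-imidazol-4-yl gives a 1.2-fold higher number from compound 2 to compound 3 (0.09 log units; within the scatter): at this place, rejoining the same atoms and going from 1 hydrogen-bond donor to 0 in the group leaves a step that stays within the scatter. The comparison with the thiazole gives a 2.7-fold higher number from compound 1 to compound 3 (0.43 log units; beyond the scatter), so both cyclopropyl-bearing groups now stand beyond the scatter of 4-methyl-1,3-thiazol-2-yl, though the step remains modest. Nothing available explains these numbers.

The compounds shown vary only the group on this carbonyl carbon, so what happens at the rest of the shared core stays open. Also open, going by these compounds, is whether a cyclopropyl-free group on this carbon, such as a ring carrying an amine or a carboxylic acid, would shift the read-out.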